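A few compounds are considered here, and "the series" means these few. Any claim that something is new, unique, unknown or untested is made for them only; others in the source may bear on it.

Of the compounds shown here, three built on one shared core have been measured in an assay on CHO cells for displacement of a labelled ligand from adenosine receptor A1 (Homo sapiens), read by scintillation counting, with a stated time of 60 min, tested at 10 uM; a lower number here means less inhibition, a higher number more inhibition at the concentration tested (going by the name of the read-out). Compound 1 `CNC(=O)[C@@]12C[C@@H]1[C@@H](n1cnc3c(NC)nc(C#Cc4ncccn4)nc31)[C@H](O)[C@@H]2O` carries pyrimidin-2-yl on a triple-bonded carbon and in this assay gives 25%. Compound 2 `CNC(=O)[C@@]12C[C@@H]1[C@@H](n1cnc3c(NC)nc(C#Cc4cnn(C)c4)nc31)[C@H](O)[C@@H]2O` carries 1-methyl-1H-pyrazol-4-yl in that place and gives 35%. Among the compounds with values here, compound 3 `CCc1ccc(C#Cc2nc(NC)c3ncn([C@H]4[C@H](O)[C@H](O)[C@]5(C(=O)NC)C[C@H]45)c3n2)o1` carries 5-ethylfuran-2-yl there and gives 18%, the smallest of the three numbers, although the step of a number 7 percentage points lower from compound 1 to compound 3 (within the scatter) is within the scatter and only the step of a number 17 percentage points lower from compound 2 to compound 3 (beyond the scatter) is beyond it. Compound 4 `CNC(=O)[C@@]12C[C@@H]1[C@@H](n1cnc3c(NC)nc(C#Cc4ccsc4)nc31)[C@H](O)[C@@H]2O` has not been measured. It differs from compound 3 in one place: thiophen-3-yl in place of 5-ethylfuran-2-yl on a triple-bonded carbon. Every measured step swaps one ring on the triple-bonded carbon, and these swaps gave a number 10 percentage points higher from compound 1 to compound 2 (within the scatter), a number 7 percentage points lower from compound 1 to compound 3 (within the scatter) and a number 17 percentage points lower from compound 2 to compound 3 (beyond the scatter), so all three values sit close together and no single swap in this place produced more than a modest shift. A further ring swap in the same place is therefore expected to give a step of a number 7 percentage points higher from compound 3 to compound 4 (within the scatter), not beyond the scatter. Compound 4 is estimated to give 25%, with a range from 10% to 40%.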

Compound 4, a percentage reported as inhibition, at one concentration (the size of the read-out at that concentration, not a potency): 11%
Beside the measured number, compound 4's estimate is 14 percentage points above it; the measured number falls inside the stated range.
By their numbers in this assay, from the lowest: compounds 4, 3, 1 and 2 (each within the scatter of the next, the first and the last beyond it).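

Replacing 5-ethylfuran-2-yl with thiophen-3-yl, a ring with fewer heavy atoms and no ethyl group, gives a number 7 percentage points lower from compound 3 to compound 4 (within the scatter). Within the data shown here, the same ring does stand apart from the other two, with a number 14 percentage points lower from compound 1 to compound 4 (beyond the scatter) and a number 24 percentage points lower from compound 2 to compound 4 (beyond the scatter), so compound 1, previously within the scatter of both other compounds, now has a step beyond it, and the modest range of effects from rings in this place is wider than the earlier compounds showed. Nothing available explains these differences.

The step to compound 4 changes the ring and removes the ethyl group together, so their separate contributions cannot be told apart. From the compounds shown here alone, it also remains open how a longer alkyl chain on the triple-bonded carbon, or a ring carrying an amine or a carboxylic acid, would compare.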